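This account rests on a few compounds, and the source may have more. Where it says the series, first, only, none or still open, it means among the compounds named here.

Measured in an ADME assay on A549 cells (Homo sapiens) for cytotoxicity, read by resazurin assay, with a stated time of 48 h; on this read-out lower numbers stand for higher toxicity in this test and higher numbers for lower toxicity in this test:
Compound 1 `O=C(Nc1ccc(NCc2ccc(O)cc2)cc1Cl)c1cc(Cl)ccc1O`: 116000 nM
Compound 2 `CN(C)c1ccc(CNc2ccc(NC(=O)c3cc(Cl)ccc3O)c(Cl)c2)cc1`: 24500 nM

Of these two, compound 2 has the lower number, 24500 nM, and so shows the higher toxicity in this assay. Among the compounds with values here, the only measured step is a 4.7-fold lower number from compound 1 to compound 2 (0.68 log units; beyond the scatter), where dimethylamino stands in place of hydroxy on an aromatic carbon.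

Compound 3 `O=C(Nc1ccc(NCc2ccncc2)cc1Cl)c1cc(Cl)ccc1O` has not yet been measured. It differs from compound 2 by having pyridin-4-yl in place of 4-(dimethylamino)phenyl on a saturated chain carbon bound to a nitrogen on an aromatic ring. This removes the dimethylamino group, so the measured step is the one that bears on the change. Within the data shown here, it is only a rough guide, as the aromatic ring itself also changes here, and no measured compound carries pyridin-4-yl. A partial return towards the number of compound 1, 116000 nM, therefore seems the most likely outcome. The expected step is a 2.4-fold higher number from compound 2 to compound 3 (0.39 log units; beyond the scatter), though this estimate is uncertain. The estimated value for compound 3 is 60000 nM, with an expected range of 20000 nM to 170000 nM.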

Compound 3, half-maximal cytotoxic concentration: 65300 nM
Compound 3: middle estimate off by 1.1-fold (0.04 log units), on the low side; low and high end bracket the measured number.
By their numbers in this assay, from the lowest: compound 2; then compounds 3 and 1 (each within the scatter of the next).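

In this assay, the group on the saturated chain carbon bound to a nitrogen on an aromatic ring can be exchanged as a whole, and this gives a 2.7-fold higher number from compound 2 to compound 3 (0.43 log units; beyond the scatter) when pyridin-4-yl stands in place of 4-(dimethylamino)phenyl. Set against the hydroxy compound, the same replacement gives a 1.8-fold lower number from compound 1 to compound 3 (0.25 log units; within the scatter) with pyridin-4-yl in place of 4-hydroxyphenyl, so compound 1 and compound 3 cannot be told apart here, and among these three compounds only compound 2, with its 4-(dimethylamino)phenyl group, stands apart from the others. No supporting data are available to explain why the numbers fall this way.

The compounds shown leave open whether the lower number of compound 2 depends on both methyl groups of the dimethylamino group, which a plain amino group on the same phenyl ring would help to test. They also leave open whether the place of the ring nitrogen matters, as pyridin-3-yl would show, and how a carboxylic acid on the phenyl ring would compare with the hydroxy and dimethylamino groups.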